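Cyclopropyl for methyl on an amine nitrogen

The source may hold more compounds than are shown below. What is called first, only, known or untested is meant among the compounds shown, and "the series" means these compounds.

The three measured compounds:
Compound 1, `COc1cc(Oc2cccc(Nc3ccccc3)c2)cc(OC)c1CNCc1ccccc1`, gives 3340 nM in a functional assay on HT-29 cells (Homo sapiens) for inhibition, read by MTT assay, with a stated time of 72 h; on this read-out lower numbers stand for stronger inhibition and higher numbers for weaker inhibition.
Compound 2, `CNCc1c(OC)cc(Oc2cccc(Nc3ccccc3)c2)cc1OC`, gives 7430 nM in this assay.
Compound 3, `COc1cc(Oc2cccc(Nc3ccccc3)c2)cc(OC)c1CNCc1ccc(C)cc1`, gives 3880 nM in this assay.

Compound 2 carries the highest number of the three. Its gap to compound 3 is within the scatter, while the step of a 2.2-fold higher number from compound 1 to compound 2 (0.35 log units; beyond the scatter) is beyond it, so compound 2 sits a little apart from compound 1 only.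

The unmeasured compound 4, `COc1cc(Oc2cccc(Nc3ccccc3)c2)cc(OC)c1CNC1CC1`, differs from compound 2 in one place: cyclopropyl in place of methyl on an amine nitrogen. The methylamino group becomes cyclopropylamino.

Going by the values given here, two measured steps touch the same amine side. Removing the phenyl there gave a 2.2-fold higher number from compound 1 to compound 2 (0.35 log units; beyond the scatter), and restoring a 4-methylphenyl gave a 1.9-fold lower number from compound 2 to compound 3 (0.28 log units; within the scatter). Both point the same way: a larger group on that side goes with a somewhat lower number, though the second step stays within the scatter. Cyclopropyl adds less than a phenyl, so in this assay a small step downward is expected, likely within the scatter, as a 1.5-fold lower number from compound 2 to compound 4 (0.17 log units; within the scatter).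

Compound 4 is therefore estimated at 5000 nM, with a plausible range from 2500 nM to 10000 nM.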

Compound 4, half-maximal inhibitory concentration: 12300 nM
Compound 4: the middle estimate sits 2.5-fold (0.39 log units) below what was measured; the whole stated range lies below it.
By their numbers in this assay, from the lowest: compounds 1, 3, 2 and 4 (each within the scatter of the next, the first and the last beyond it).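

In this assay, the step of a 1.7-fold higher number from compound 2 to compound 4 (0.22 log units; within the scatter) stays within the scatter, so exchanging methyl for cyclopropyl on this amine nitrogen gives no readable change, and the extra carbons and the three-membered ring do not lower the number. Going by these compounds alone, the clear separation lies elsewhere: a 3.2-fold higher number from compound 3 to compound 4 (0.50 log units; beyond the scatter) and a 3.7-fold higher number from compound 1 to compound 4 (0.57 log units; beyond the scatter) are both beyond the scatter, so at this nitrogen the benzyl and 4-methylbenzyl groups stand apart from cyclopropyl, and compound 4 goes against the idea, drawn from the earlier compounds, that any larger group here brings a lower number. Nothing in the available data explains this difference between the groups.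

The compounds shown leave open whether the benzyl groups stand apart for their aromatic ring or simply for their larger number of atoms, a question that a cyclohexylmethyl group on the same nitrogen could help to settle. Going by these compounds, it also remains open how an ethyl or isopropyl group would compare with methyl and cyclopropyl, and whether a second methyl on the nitrogen, giving a dimethylamino group, would change the number at all.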